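Chain change from compound 3 to compound 4

The compounds below may be only part of what the source reports. "The series", "measured", "known", "first", "only" and "open" are said of these compounds alone.

Measured in an in vitro ADME assay on microsomes from liver (Homo sapiens) for metabolic stability, tested at 5 uM; on this read-out lower numbers stand for a shorter-lived compound and higher numbers for a longer-lived compound:
- compound 1 `CC(C)CCn1nc(C2CCCC2)c(O)c(C2=NS(=O)(=O)c3cc(NS(C)(=O)=O)ccc3N2)c1=O`: 0.283 h
- compound 2 `CC(C)CCn1nc(C2=CCCC2)c(O)c(C2=NS(=O)(=O)c3cc(NS(C)(=O)=O)ccc3N2)c1=O`: 0.933 h
- compound 3 `CCC(C)CCn1nc(-c2cccs2)c(O)c(C2=NS(=O)(=O)c3cc(NS(C)(=O)=O)ccc3N2)c1=O`: > 1 h (a limit, not a number)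

Compound 3 stands at the limit of > 1 h in this assay, at which 1 of the 3 values shown sits, so its place on the scale is known only as a limit. Compound 4 `CCCC(C)n1nc(-c2cccs2)c(O)c(C2=NS(=O)(=O)c3cc(NS(C)(=O)=O)ccc3N2)c1=O` keeps the thiophen-2-yl group and differs from compound 3 only in the chain on the aromatic nitrogen, with 1-methylbutyl in place of 3-methylpentyl (1-methylbutyl in place of 3-methylpentyl on an aromatic nitrogen).

Within the data shown here, no measured step changes that chain alone. Among the measured compounds shown here, the single measured step is a 3.3-fold higher number from compound 1 to compound 2 (0.52 log units; beyond the scatter), with cyclopent-1-en-1-yl in place of cyclopentyl on an aromatic carbon. That step is at a different place in the molecule, so it offers only a rough size for one change in this assay and no direction for this one. On the size of a 3.3-fold higher number from compound 1 to compound 2 (0.52 log units; beyond the scatter), a step of similar or smaller size is expected for the chain change, most likely a modest drop from the limit held by compound 3. The expected change is an at least 1.1-fold lower number from compound 3 to compound 4 (0.04 log units; that floor lies within the scatter), and this remains an estimate. For compound 4 the estimated half-life is 0.9 h, with an expected range of 0.4 h to 1.8 h.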

Compound 4, half-life: > 1 h
Compound 4: only a limit was reported; the forecaster's own chance of this, stated with the estimate: 45%; at least 1.1-fold (0.04 log units) between middle value and limit.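

In this assay compound 3 gives > 1 h, a limit and not a number. Compound 4 gives > 1 h, also a limit, so no step can be read between these two compounds: the limit of > 1 h in this assay, at which 2 of the 4 values shown sit.

The compounds shown leave open how the half-life of compound 4 compares with that of compound 3, and so what 1-methylbutyl in place of 3-methylpentyl does to the read-out.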